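This account rests on a few compounds, and the source may have more. Where it says the series, first, only, none or still open, it means among the compounds named here.

Of the compounds shown here, three have so far been tested in a functional assay on LNCaP cells (Homo sapiens) for cytotoxicity; a lower number here means a stronger inhibitor, a higher number a weaker inhibitor. Compound 1, `COc1ccc(Cn2cc(/C=N\NC(=O)c3c[nH]c4ccccc34)c3ccccc32)cc1`, gives 31900 nM. Compound 2, `COc1ccc(Cn2cc(/C=N\NC(=O)c3c[nH]c4ccccc34)c3cc(OC)ccc32)cc1`, carries one extra methoxy group on an aromatic carbon of its core; in this assay compound 2 gives > 100000 nM, which is a limit of the assay and not a number. That single change produced an at least 3.1-fold higher number from compound 1 to compound 2 (0.49 log units; beyond the scatter), so the methoxy made the compound weaker. Compound 3, `O=C(N/N=C\c1cn(Cc2ccc(Cl)cc2)c2cc(F)ccc12)c1c[nH]c2ccccc12`, gives 55200 nM; its number and that of compound 1 lie within the usual scatter of each other, so neither can be called the stronger of the two. Compound 4, `O=C(N/N=C\c1cn(Cc2ccc(Cl)cc2)c2cc(F)ccc12)c1c[nH]c2ccc(Br)cc12`, differs from compound 3 by bromo in place of hydrogen on an aromatic carbon. Among the compounds with values here, the only measured step that bears on this is the one from compound 1 to compound 2, which also placed a substituent on an aromatic carbon of an indole part and weakened the compound, though with a different group on a different ring, so it is a loose guide at best. For compound 4 the expected step is a 1.4-fold higher number from compound 3 to compound 4 (0.13 log units; within the scatter), a weakening that may not exceed the scatter. Compound 4 is therefore estimated at 75000 nM, within 25000 nM to 200000 nM.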

Compound 4, half-maximal inhibitory concentration: 24800 nM
Compound 4: middle estimate off by 3.0-fold (0.48 log units), on the high side; measured number outside the range, below it.
By their numbers in this assay, from the lowest: compounds 4, 1 and 3 (each within the scatter of the next, the first and the last beyond it). At a limit, above all of these: compound 2.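

In this assay, replacing hydrogen with bromo on this aromatic carbon, which turns 1H-indol-3-yl into 5-bromo-1H-indol-3-yl, gave a 2.2-fold lower number from compound 3 to compound 4 (0.35 log units; beyond the scatter), a modest gain in strength. The earlier step with a measured direction went the opposite way, with a different group in a different place, so a new substituent on an aromatic carbon does not always weaken these compounds. Nothing measured here explains why bromo has this effect.

Within the data shown here, this position has been tested with only one group, so it remains open whether the gain is particular to bromo. An amine, a nitrile or a carboxylic acid on the same carbon would show whether other groups also lower the number or instead raise it.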